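Compound 3: 2-nitrophenyl in place of 4-bromophenyl

The source may report more compounds than this note shows. Statements on the series, on what has been measured and on what is new or still open speak of the compounds shown alone.

Compound 1 `COc1cc(C(=O)c2cn(-c3ccccc3)cc2-c2ccccc2C)cc(OC)c1OC`: 190 nM
Compound 2 `COc1cc(C(=O)c2cn(-c3ccccc3)cc2-c2ccc(Br)cc2)cc(OC)c1OC`: 340 nM

Among the measured compounds shown here, in a functional assay on MCF7 cells (Homo sapiens) for cytotoxicity, read by MTT assay, with a stated time of 96 h (a lower number here means a stronger inhibitor, a higher number a weaker inhibitor), compound 2 gives 340 nM, the higher of the two numbers so far, yet within the scatter of compound 1 at 190 nM. The next compound, compound 3 `COc1cc(C(=O)c2cn(-c3ccccc3)cc2-c2ccccc2[N+](=O)[O-])cc(OC)c1OC`, carries 2-nitrophenyl in place of 4-bromophenyl on an aromatic carbon of a five-membered aromatic ring with 1 nitrogen (2-nitrophenyl in place of 4-bromophenyl on an aromatic carbon). For the measured compounds named here, only one measured step bears on this change: a 1.8-fold higher number from compound 1 to compound 2 (0.25 log units; within the scatter), with 4-bromophenyl in place of 2-methylphenyl at that same carbon. Going by the values given here, no compound with a nitro group has been measured, so this single step is a thin guide. It gives no reason to expect a step beyond the scatter in this assay. The expected change is a 1.4-fold lower number from compound 2 to compound 3 (0.13 log units; within the scatter). The estimate for compound 3 is 250 nM, with an expected range of 80 nM to 800 nM.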

Compound 3, half-maximal inhibitory concentration: 49 nM
For compound 3 the middle estimate is 5.1-fold (0.71 log units) above the measured one; measured number below the stated range.
By their numbers in this assay, from the lowest: compound 3; then compounds 1 and 2 (each within the scatter of the next).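

In this assay, the earlier step at this carbon of the five-membered aromatic ring stayed within the scatter, but this change moves the number well beyond it (a 6.9-fold lower number from compound 2 to compound 3 (0.84 log units; beyond the scatter)). The closer comparison keeps the substituted phenyl and swaps only methyl for nitro on an aromatic carbon (a 3.9-fold lower number from compound 1 to compound 3 (0.59 log units; beyond the scatter)), so the lower number goes with the nitro group itself and not merely with the loss of 4-bromophenyl. Nothing measured here accounts for this difference.

The compounds shown leave open whether 4-nitrophenyl would match 2-nitrophenyl, so the part played by the place of the nitro group on that ring remains unknown. They also leave open whether an amine, as in 2-aminophenyl, or a nitrile, as in 2-cyanophenyl, would track with nitro or with methyl.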